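The compounds below may be only part of what the source reports. "The series", "measured", "known", "first", "only" and "open" are said of these compounds alone.

In a functional assay on HL-60 cells (Homo sapiens) for antiproliferative activity, read by XTT assay, with a stated time of 72 h (a lower number here means a stronger inhibitor, a higher number a weaker inhibitor), compound 1 `Nc1nc(N)c2c(-c3cc4ccccc4o3)cn([C@@H]3O[C@H](CO)[C@@H](O)[C@H]3O)c2n1` gives > 15000 nM as its result, and this is a limit of the assay, not a number. Its standing is therefore known only as a limit. Compound 2 `Cc1nc(N)c2c(-c3cc4ccccc4o3)cn([C@@H]3O[C@H](CO)[C@@H](O)[C@H]3O)c2n1` gives > 20000 nM as its result, which is also a limit. Compound 3 `COc1nc(N)nc2c1c(-c1cc3ccccc3o1)cn2[C@@H]1O[C@H](CO)[C@@H](O)[C@H]1O` has not yet been measured. It differs from compound 1 by methoxy in place of amino on an aromatic carbon and the change sits next to the ring nitrogen and ortho to a fused ring. Going by the values given here, the only measured change that bears on this is a step that the two limits leave unreadable from compound 1 to compound 2 and it replaced the other amino group, the one that compound 3 keeps. With that single unreadable step as a guide, no step beyond the scatter is expected in this assay and no direction can be given. The expected change is a step that the limit leaves unreadable from compound 1 to compound 3 as an estimate. Compound 3 is estimated at 18000 nM with an expected range from 6000 nM to 40000 nM and the assay may well report only a limit.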

Compound 3, half-maximal inhibitory concentration: > 20000 nM
Compound 3 ended at the assay's limit; the forecaster's own chance of this, stated with the estimate: 75%; middle value at least 1.1-fold (0.04 log units) away from the limit.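

In this assay, going by these compounds alone, the results for compound 1 and compound 3 are both limits of the assay and not numbers, and no step between the two can be read. The compounds shown leave open how strongly each of them really acts on these cells, and whether methoxy in place of amino changes that at all.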